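Swapping fluoro for methoxy on a weak pyrazoline inhibitor

The source may report more compounds than this note shows. Statements on the series, on what has been measured and on what is new or still open speak of the compounds shown alone.

Measured compounds:
compound 1 `CCC(=O)N1N=C(c2ccc(Cl)cc2)CC1c1ccc(Cl)cc1`: 200 nM
compound 2 `CCC(=O)N1N=C(c2ccc(F)cc2)CC1c1ccc(Cl)cc1`: 1410 nM
compound 3 `CCC(=O)N1N=C(c2ccc(F)cc2)CC1c1ccc(C)cc1`: 10000 nM

These three compounds share one core and were tested in an assay on isolated protein for inhibition of Amine oxidase [flavin-containing] A (Bos taurus); on this read-out lower numbers stand for stronger inhibition and higher numbers for weaker inhibition. Compound 3 gives the highest number of the three, so it is the weakest inhibitor here: the nearest is compound 2, and compound 1 sits furthest away with the lowest number. The two known steps are a 7.1-fold higher number from compound 1 to compound 2 (0.85 log units; beyond the scatter) and a 7.1-fold higher number from compound 2 to compound 3 (0.85 log units; beyond the scatter), each a change of one group on an aromatic carbon.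

Compound 4 `CCC(=O)N1N=C(c2ccc(OC)cc2)CC1c1ccc(C)cc1` is not yet measured. It differs from compound 3 by methoxy in place of fluoro on an aromatic carbon. Going by the values given here, only the step from compound 1 to compound 2 touches this same place, where fluoro in place of chloro raised the number. Nothing measured tells how methoxy compares with fluoro there, so the direction is uncertain. Given the large numbers for compound 3, the expectation is a change of a 1.4-fold lower number from compound 3 to compound 4 (0.15 log units; within the scatter), likely small and possibly within scatter, in this assay. Compound 4 is estimated at 7000 nM, with a range from 2500 nM to 20000 nM.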

Compound 4, half-maximal inhibitory concentration: 7240 nM
Estimate against measurement, compound 4: 1.0-fold (0.01 log units) below; the measured number falls inside the stated range.
By their numbers in this assay, from the lowest: compound 1; then compound 2; then compounds 4 and 3 (each within the scatter of the next).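

On the aromatic ring of compound 3 that carries fluoro, methoxy brings a hydrogen-bond acceptor where fluoro has none, yet this assay records only a 1.4-fold lower number from compound 3 to compound 4 (0.14 log units; within the scatter) and so cannot tell the two groups apart. Going by these compounds alone, the only earlier change at this place, fluoro in place of chloro, gave a 7.1-fold higher number from compound 1 to compound 2 (0.85 log units; beyond the scatter) with chloro on the other aromatic ring, so this place does not respond to every swap in the same way, although the new step was read with methyl on that other ring. Nothing available explains why fluoro and methoxy read alike here, or why the earlier swap at this place gave a clear step.

The compounds shown leave open whether methoxy and fluoro would also read alike with chloro on the other ring, since the step here comes from a single pair with methyl there. They also leave open how this place would respond to a group unlike those seen so far, such as an amine, a carboxylic acid or a longer chain like ethoxy or butoxy in place of methoxy.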